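Replacing a Methoxy Group with a Methylpyrazole on the Pyridine

This account rests on a few compounds, and the source may have more. Where it says the series, first, only, none or still open, it means among the compounds named here.

Measured so far:
- compound 1, `Cc1[nH]ncc1-c1cncc(-c2ccc(C(N)=O)c(OC(C)C)c2)c1`: 54 nM
- compound 2, `COc1cncc(-c2ccc(C(N)=O)cc2)c1`: 3000 nM

In an assay on cells for inhibition of MAP kinase-interacting serine/threonine-protein kinase 1 (Homo sapiens), read by mobility shift assay, with stated times of 10 min and 60 min, in the presence of a further agent that is not named here (a higher number here means a weaker inhibitor, a lower number a stronger inhibitor), compound 2 gives the highest of the two numbers, so it is the weaker of the two measured compounds. Its nearest neighbour is compound 1, whose number is lower by a margin well beyond the usual scatter. For the measured compounds named here, compound 1 differs from compound 2 in more than one place, so no single step between measured compounds is available.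

Compound 3, `Cn1cc(-c2cncc(-c3ccc(C(N)=O)cc3)c2)cn1`, has not yet been measured. It differs from compound 2 in one way: 1-methyl-1H-pyrazol-4-yl in place of methoxy on an aromatic carbon. Because compound 1, which also carries a pyrazole on that ring, gives 54 nM, a clear gain over compound 2 seems plausible for compound 3, though the other difference in compound 1 leaves the size uncertain.

The step from compound 2 to compound 3 in this assay is expected to be a sizeable fall, a 7.5-fold lower number from compound 2 to compound 3 (0.88 log units; beyond the scatter), beyond the scatter. Compound 3 is therefore estimated at 400 nM, most likely between 100 nM and 1500 nM.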

Compound 3, half-maximal inhibitory concentration: 800 nM
Estimate against measurement, compound 3: 2.0-fold (0.30 log units) below, and the stated range covers the measured number.
By their numbers in this assay, from the lowest: compound 1; then compound 3; then compound 2.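

In this assay, this position on the pyridine now has its first reading for a single change: swapping methoxy for 1-methyl-1H-pyrazol-4-yl gives a 3.8-fold lower number from compound 2 to compound 3 (0.57 log units; beyond the scatter) and counts as a modest gain. The entering group has 6 heavy atoms against 2 and brings a five-membered aromatic ring, so this place on the core takes a much larger substituent with no loss of inhibition, and methoxy is not needed there. Nothing available explains the gain, so it stands only as an observed change in the measured number.

The compounds shown cannot separate the contribution of the pyrazole ring from that of its methyl group, nor say whether a simple amine, a carboxylic acid or a longer alkyl chain at the same carbon would do as well or better. On these data alone, it also remains open whether this gain would carry over to a core with other substituents, since a single step on one core says nothing about how the change behaves elsewhere.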